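Swapping the benzylic aryl group: furan to naphthalene

The source may hold more compounds than are shown below. What is called first, only, known or untested is meant among the compounds shown, and "the series" means these compounds.

Measured compounds in a toxicity assay on A549 cells (Homo sapiens) for cytotoxicity, read by luminescence and CellTiter-Glo, with a stated time of 48 h; a higher number here means that more compound is tolerated, a lower number that less compound is tolerated:
- compound 1 `CCCCOc1ccc(-c2nc3ncccn3c2NCC2CCCCC2)cc1` gives 35000 nM
- compound 2 `CCCCOc1ccc(-c2nc3ncccn3c2NCc2ccc(OC)cc2)cc1` gives 55000 nM
- compound 3 `CCCCOc1ccc(-c2nc3ncccn3c2NCc2ccco2)cc1` gives 78000 nM

Compound 3 holds the highest number of the three; it sits within the scatter of compound 2 and only modestly beyond that of compound 1. Compound 4 `CCCCOc1ccc(-c2nc3ncccn3c2NCc2ccc3ccccc3c2)cc1` differs from compound 3 by naphthalen-2-yl in place of furan-2-yl on a saturated chain carbon bound to a nitrogen on an aromatic ring. Within the data shown here, the steps that bear on this position are a 2.2-fold higher number from compound 1 to compound 3 (0.35 log units; beyond the scatter) and a 1.4-fold higher number from compound 2 to compound 3 (0.15 log units; within the scatter), neither large. Across cyclohexyl, 4-methoxyphenyl and furan-2-yl on that carbon the spread in this assay is narrow, so a naphthalen-2-yl group is expected to give no step beyond the scatter, with a slight lean toward a lower number. Compound 4 is therefore estimated at 50000 nM, range 22000 nM to 115000 nM, an expected step of a 1.6-fold lower number from compound 3 to compound 4 (0.19 log units; within the scatter).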

Compound 4, half-maximal cytotoxic concentration: 33000 nM
Estimate against measurement, compound 4: 1.5-fold (0.18 log units) above, and the stated range covers the measured number.
By their numbers in this assay, from the lowest: compounds 4, 1, 2 and 3 (each within the scatter of the next, the first and the last beyond it).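

In this assay a second group on the saturated chain carbon bound to a nitrogen on an aromatic ring separates from furan-2-yl, with a 2.4-fold lower number from compound 3 to compound 4 (0.37 log units; beyond the scatter) as a modest step. Naphthalen-2-yl stays within the scatter of both other groups, with a 1.7-fold lower number from compound 2 to compound 4 (0.22 log units; within the scatter) and a 1.1-fold lower number from compound 1 to compound 4 (0.03 log units; within the scatter), so it cannot be told apart from 4-methoxyphenyl or cyclohexyl here. Nothing at hand explains these differences. On these data alone, whether an amine, a carboxylic acid or a longer chain on this carbon would move the number remains open. So does whether any group here gives more than a modest step.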